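This account rests on a few compounds, and the source may have more. Where it says the series, first, only, none or still open, it means among the compounds named here.

Three compounds with a nitroimidazole-bearing chain have numbers in a functional assay on HT-29 cells (Homo sapiens) for inhibition, read by sulforhodamine B assay, with a stated time of 72 h; a higher number here means a weaker inhibitor, a lower number a stronger inhibitor: compound 1 (`COc1cc2c(Nc3ccc(F)c(Cl)c3)ncnc2cc1OCCOCCn1ccnc1[N+](=O)[O-]`), compound 2 (`COc1cc2c(Nc3cccc(Br)c3)ncnc2cc1OCCCCn1ccnc1[N+](=O)[O-]`) and compound 3 (`COc1cc2c(Nc3cccc(Br)c3)ncnc2cc1OCCCCCn1ccnc1[N+](=O)[O-]`). Compound 3 gives 2540 nM, within the scatter of compound 2 at 1430 nM, while compound 1 stands clearly higher at 5520 nM. Compound 4 (`COc1cc2c(Nc3cccc(Br)c3)ncnc2cc1OCCOCCn1ccnc1[N+](=O)[O-]`) differs from compound 3 only in the chain: 2-(2-nitro-1H-imidazol-1-yl)ethoxy in place of 3-(2-nitro-1H-imidazol-1-yl)propyl on a saturated chain carbon, two bonds along the chain from an oxygen on an aromatic ring. Among the compounds with values here, the one measured chain step, a 1.8-fold higher number from compound 2 to compound 3 (0.25 log units; within the scatter), changes chain length only, so it offers limited guidance. Compound 1, at 5520 nM, shares the 2-(2-nitro-1H-imidazol-1-yl)ethoxy group but differs elsewhere, so it hints weakly upward. The expected step is therefore small and stays within the scatter: a 1.4-fold higher number from compound 3 to compound 4 (0.14 log units; within the scatter). Compound 4 is estimated at 3500 nM, with an expected range of 1600 nM to 7500 nM.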

Compound 4, half-maximal inhibitory concentration: 3440 nM
Estimate against measurement, compound 4: 1.0-fold (0.01 log units) above, within the range that was stated.
By their numbers in this assay, from the lowest: compounds 2, 3, 4 and 1 (each within the scatter of the next, the first and the last beyond it).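

In this assay, an oxygen in place of a chain carbon gives a 1.4-fold higher number from compound 3 to compound 4 (0.13 log units; within the scatter), so 2-(2-nitro-1H-imidazol-1-yl)ethoxy and 3-(2-nitro-1H-imidazol-1-yl)propyl cannot be told apart here. Set against 2-(2-nitro-1H-imidazol-1-yl)ethyl, the same ethoxy group gives a 2.4-fold higher number from compound 2 to compound 4 (0.38 log units; beyond the scatter), a modest step just beyond the scatter, whereas 3-bromophenyl in place of 3-chloro-4-fluorophenyl gives a 1.6-fold lower number from compound 1 to compound 4 (0.21 log units; within the scatter). No supporting measurement explains any of these steps. Still open, as far as these compounds go, is how an amine in the chain or a longer chain would read at this place, and whether the nitroimidazole itself contributes to these numbers.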